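A few compounds are considered here, and "the series" means these few. Any claim that something is new, unique, unknown or untested is made for them only; others in the source may bear on it.

In a functional assay on KYSE-450 cells (Homo sapiens) for inhibition, read by MTT assay, with a stated time of 48 h (a higher number here means a weaker inhibitor, a lower number a stronger inhibitor), the measured compounds read as follows:
compound 1 `C/C=C/C(=O)N(Cc1ccc(OC)c([N+](=O)[O-])c1)c1cc(OC)c(OC)c(OC)c1` gives 510 nM
compound 2 `COc1ccc(CNc2cc(OC)c(OC)c(OC)c2)cc1[N+](=O)[O-]` gives 16800 nM
compound 3 `COc1ccc(CN(C(=O)CCCl)c2cc(OC)c(OC)c(OC)c2)cc1O` gives 110 nM

Compound 2 has the highest number of the three and is therefore the weakest inhibitor here. Compound 4 `COc1ccc(CNc2cc(OC)c(OC)c(OC)c2)cc1C` keeps the core of compound 2 with one change methyl in place of nitro on an aromatic carbon and the place of that change is ortho to a methoxy group.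

For the measured compounds named here, the only measured step of a 33-fold higher number from compound 1 to compound 2 (1.52 log units; beyond the scatter) is large and beyond the scatter, but it puts hydrogen in place of (prop-1-en-1-yl)carbonyl on a nitrogen, not at the place that changes now. Compound 4 keeps that hydrogen, as compound 2 does. Going by the values given here, no measured step replaces nitro, so the data give no direction, and no step beyond the scatter is expected in this assay on this evidence. The estimate is an expected 1.4-fold lower number from compound 2 to compound 4 (0.15 log units; within the scatter) and no more than that. For compound 4 the estimated value is 12000 nM with an expected range from 4000 nM to 35000 nM as the likely span.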

Compound 4, half-maximal inhibitory concentration: 73800 nM
The estimate for compound 4 lay 6.2-fold (0.79 log units) below the measured number, and the stated range ends below it.
By their numbers in this assay, from the lowest: compound 3; then compound 1; then compound 2; then compound 4.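

The change shows that this aromatic carbon, ortho to a methoxy group, is not indifferent in this assay: with the hydrogen on the nitrogen kept, methyl in place of nitro gives a 4.4-fold higher number from compound 2 to compound 4 (0.64 log units; beyond the scatter). For the compounds shown here, the earlier compounds offered no measured step at this place, so this is the first direction read there, and it favours nitro over methyl as the stronger inhibitor of this pair. The step is modest, but it lies beyond the scatter. Nothing measured here accounts for the difference between the two groups.

As far as these compounds go, whether an amine or a nitrile at this place would read closer to compound 2 or to compound 4 remains open. Also open, from the compounds shown here alone, is whether the same swap would have the same size with the (prop-1-en-1-yl)carbonyl of compound 1 on the nitrogen.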